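The source may hold more compounds than are shown below. What is called first, only, known or untested is meant among the compounds shown, and "the series" means these compounds.

Measured so far in a functional assay on CCRF-CEM cells (Homo sapiens); on this read-out higher numbers stand for lower toxicity in this test and lower numbers for higher toxicity in this test:
compound 1, `COC(=O)CNC1=CS(=O)(=O)O[C@@]12[C@@H](CO[Si](C)(C)C(C)(C)C)O[C@@H](n1cc(C)c(=O)n(C)c1=O)[C@@H]2O[Si](C)(C)C(C)(C)C`: 96000 nM
compound 2, `COC(=O)CC(=O)NC1=CS(=O)(=O)O[C@@]12[C@@H](CO[Si](C)(C)C(C)(C)C)O[C@@H](n1cc(C)c(=O)n(C)c1=O)[C@@H]2O[Si](C)(C)C(C)(C)C`: 29700 nM

Among these two numbers compound 2 stands lowest, with compound 1 above it by a 3.2-fold lower number from compound 1 to compound 2 (0.51 log units; beyond the scatter) read backwards. Compound 3, `COC(=O)CCNC1=CS(=O)(=O)O[C@@]12[C@@H](CO[Si](C)(C)C(C)(C)C)O[C@@H](n1cc(C)c(=O)n(C)c1=O)[C@@H]2O[Si](C)(C)C(C)(C)C`, has not yet been measured. Its change from compound 2 is 2-(methoxycarbonyl)ethyl in place of ((methoxycarbonyl)methyl)carbonyl on an amine nitrogen. Among the measured compounds shown here, the only step seen so far, a 3.2-fold lower number from compound 1 to compound 2 (0.51 log units; beyond the scatter), went the other way: a chain on the amine nitrogen became a carbonyl-bearing chain, and the number fell. Compound 3 returns to a plain chain on the amine nitrogen, one carbon longer than in compound 1, so this step bears directly on the change and suggests a movement back upward, beyond the scatter, though the longer chain adds some uncertainty. Compound 3 is therefore expected to give 70000 nM in this assay, between 25000 nM and 200000 nM, a step of a 2.4-fold higher number from compound 2 to compound 3 (0.37 log units; beyond the scatter).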

Compound 3, half-maximal cytotoxic concentration: > 250000 nM
Compound 3: no number, only a limit; the forecaster's own chance of this, stated with the estimate: 10%; middle value at least 3.5-fold (0.55 log units) from the limit.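

In this assay, compound 3 gives a limit and not a number: the limit of > 250000 nM in this assay, at which 1 of the 3 values shown sits. Among the compounds shown here, putting 2-(methoxycarbonyl)ethyl in place of ((methoxycarbonyl)methyl)carbonyl on the amine nitrogen gives an at least 8.4-fold higher number from compound 2 to compound 3 (0.92 log units; beyond the scatter), so the chain with the extra carbonyl remains the one with the lowest number, which here means the highest toxicity in this test. The plain chains also differ from each other, with an at least 2.6-fold higher number from compound 1 to compound 3 (0.41 log units; beyond the scatter), so at this position the length of the chain moves the number as well as the carbonyl does.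

From the compounds shown here alone, since compound 3 ends at a limit, the true size of both steps stays open at the upper end. Also open, going by these compounds, is how a longer chain, or a carboxylic acid in place of the methyl ester, would behave on this nitrogen.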